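Swapping a benzyl for a butyl on the sulfur

The compounds below may be only part of what the source reports. "The series", "measured", "known", "first", "only" and "open" are said of these compounds alone.

Compound 1 `CCCSc1nc(N)c2nc(O)n(Cc3ccccc3)c2n1`: 0.01 uM in a functional assay (spleen, spleen) for activation, with Mus musculus as the target; a higher number here means that more compound is needed for the effect, a lower number that less compound is needed
Compound 2 `Nc1nc(SCc2ccccc2)nc2c1nc(O)n2Cc1ccccc1`: 0.1 uM in this assay

Two compounds share one core and differ only in the group on the sulfur. Within the data shown here, compound 2 stands at the highest of the two numbers in this assay, and its nearest neighbour is compound 1, whose number is lower; the single step between them, a 10-fold higher number from compound 1 to compound 2 (1.00 log units; beyond the scatter), is beyond the scatter.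

Compound 3 `CCCCSc1nc(N)c2nc(O)n(Cc3ccccc3)c2n1` is not yet measured. It differs from compound 2 by propyl in place of phenyl on a saturated chain carbon bound to a sulfur. Among the measured compounds shown here, this is close to the reverse of the one measured step: going from compound 1 to compound 2 exchanged an alkyl group for phenyl and raised the number; compound 3 exchanges phenyl for an alkyl group again, one carbon longer than in compound 1. For the measured compounds named here, that single step is the only evidence here, so the expectation rests on it alone. Compound 3 is therefore expected to return to roughly the level of compound 1, an estimated 0.015 uM with a range of 0.004 uM to 0.06 uM, which would mean a step of a 6.7-fold lower number from compound 2 to compound 3 (0.82 log units; beyond the scatter) in this assay.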

Compound 3, minimum effective concentration: 0.01 uM
Beside the measured number, compound 3's estimate is 1.5-fold (0.18 log units) above it; the measured number falls inside the stated range.
By their numbers in this assay, from the lowest: compounds 1 and 3 (each within the scatter of the next); then compound 2.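

In this assay, the change from a benzyl to a butyl on the sulfur gives a 10-fold lower number from compound 2 to compound 3 (1.00 log units; beyond the scatter), so the effect seen with the first swap also appears in the opposite direction and on a different chain. Among these compounds, the other new comparison gives no change at the digits printed from compound 1 to compound 3 (within the scatter), which shows that this assay does not separate the propyl and butyl groups, even though they differ by one chain carbon; among the three compounds, the benzyl of compound 2 is the only group that stands apart. No measurement shown here speaks to what lies behind the gap between the benzyl and the two straight chains.

The compounds shown leave open how far this flat response to chain length extends, since a longer chain such as hexyl or a shorter one such as methyl could fall on either side of the values seen so far. They also leave open whether the higher number belongs to the benzyl group in particular, which a phenyl placed directly on the sulfur, a phenethyl group or a cyclohexylmethyl group could help to test.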